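The source may hold more compounds than are shown below. What is called first, only, known or untested is meant among the compounds shown, and "the series" means these compounds.

Three compounds with a shared core were measured in a functional assay on A-375 cells (Homo sapiens) for cytotoxicity, read by MTT assay, with a stated time of 72 h; a higher number here means a weaker inhibitor, a lower number a stronger inhibitor. Compound 1, `O=C1c2c[n+]([O-])c3ccccc3c2C(=O)c2c1c1ccccc1n2Cc1cn([C@H]2C[C@H](O)[C@@H](CO)O2)nn1`, gives 390 nM. For the measured compounds named here, compound 3, `CC1(C)OC[C@H](Cn2cc(Cn3c4c(c5ccccc53)C(=O)c3c[n+]([O-])c5ccccc5c3C4=O)nn2)O1`, gives 180 nM; the step of a 2.2-fold lower number from compound 1 to compound 3 (0.34 log units; beyond the scatter) is the only measured change with a single point of difference. Compound 2, `O=C1c2c[n+]([O-])c3ccccc3c2C(=O)c2c1c1ccccc1n2CCCCN1CCNCC1`, gives 460 nM, which stands highest of the three; compared with compound 1 the gap lies within the scatter, while compared with compound 3 the gap lies beyond it.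

Compound 4, `O=C1c2c[n+]([O-])c3ccccc3c2C(=O)c2c1c1ccccc1n2CCN1CCCCC1`, is not yet measured. It differs from compound 2 by piperidin-1-yl in place of 2-(piperazin-1-yl)ethyl on a saturated chain carbon, two bonds along the chain from an aromatic nitrogen. Going by the values given here, no measured step touches this chain; the one measured step, between compound 1 and compound 3, concerns a group on an aromatic nitrogen and was modest, so it gives no direct guide. With the change at the chain end and nothing to anchor a direction, the number for compound 4 is expected to stay near that of compound 2, with a 1.1-fold lower number from compound 2 to compound 4 (0.04 log units; within the scatter) expected to lie within the scatter. The estimate for compound 4 is 420 nM, in a range from 150 nM to 1200 nM.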

Compound 4, half-maximal inhibitory concentration: 180 nM
Compound 4: middle estimate off by 2.3-fold (0.37 log units), on the high side; the range from low to high includes it.
By their numbers in this assay, from the lowest: compounds 3 and 4 (each within the scatter of the next); then compounds 1 and 2 (each within the scatter of the next).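

In this assay, the exchange of 2-(piperazin-1-yl)ethyl for piperidin-1-yl, on a saturated chain carbon, two bonds along the chain from an aromatic nitrogen, gives a 2.6-fold lower number from compound 2 to compound 4 (0.41 log units; beyond the scatter), so the earlier flat reading of compound 2 against compound 1 did not mean that this position tolerates any change. The same difference also reads as 4-(piperazin-1-yl)butyl to 2-(piperidin-1-yl)ethyl, so chain length and ring change together and this step cannot separate them. Nothing available accounts for the step.

Open, from the compounds shown here alone, is whether piperazin-1-yl on the ethyl chain, or piperidin-1-yl on the butyl chain, would stand nearer compound 2 or compound 4. Also open, going by these compounds, is how a morpholine or a dimethylamino group in place of the piperidin-1-yl would compare.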